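A New Side Chain on an Amide-Type Nitrogen

The source may report more compounds than this note shows. Statements on the series, on what has been measured and on what is new or still open speak of the compounds shown alone.

Of the compounds shown here, two have been measured so far. Within the data shown here, compound 1 `CCN(CC)CCNC(=O)Nc1nc2ccc(-c3cnc(OC)c(NS(=O)(=O)c4ccc(F)cc4)c3)cc2s1` and compound 2 `O=C(Nc1nc2ccc(-c3cnc(Cl)c(NS(=O)(=O)c4ccc(F)cc4)c3)cc2s1)NC1CC1` share the same core but differ in two places, so no single-change step links them. In a functional assay on MCF7 cells (Homo sapiens) for antiproliferative activity, read by MTT assay, with a stated time of 72 h (a lower number here means a stronger inhibitor, a higher number a weaker inhibitor), compound 1 gives 320 nM, while compound 2 gives 1090 nM, the higher of the two numbers. Compound 3 `CCN(CC)CCNC(=O)Nc1nc2ccc(-c3cnc(Cl)c(NS(=O)(=O)c4ccc(F)cc4)c3)cc2s1` is compound 2 with 2-(diethylamino)ethyl in place of cyclopropyl on an amide-type nitrogen. Because compound 1 carries this same side chain and gives 320 nM, the step is expected to run moderately downward, about a 2.2-fold lower number from compound 2 to compound 3 (0.34 log units; beyond the scatter). Compound 3 is estimated at 500 nM, within a range from 150 nM to 1600 nM.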

Compound 3, half-maximal inhibitory concentration: 710 nM
Compound 3: middle estimate off by 1.4-fold (0.15 log units), on the low side; the range from low to high includes it.
By their numbers in this assay, from the lowest: compound 1; then compounds 3 and 2 (each within the scatter of the next).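

Putting 2-(diethylamino)ethyl in place of cyclopropyl on the amide-type nitrogen gives a 1.5-fold lower number from compound 2 to compound 3 (0.19 log units; within the scatter) in this assay, so this change does not clearly separate the two compounds. With that side chain held the same, chloro in place of methoxy on an aromatic carbon gives a 2.2-fold higher number from compound 1 to compound 3 (0.35 log units; beyond the scatter), a modest step that lies beyond the scatter. Nothing available explains either step.

A compound pairing cyclopropyl with methoxy would show whether the side chain matters with methoxy present. Going by these compounds, a morpholine-ended chain on this nitrogen, or fluoro or methyl on the aromatic carbon, also remains open.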